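Chloro for methyl at the assay limit

A few compounds are considered here, and "the series" means these few. Any claim that something is new, unique, unknown or untested is made for them only; others in the source may bear on it.

Of the compounds shown here, two have been read so far. In a functional assay on HeLa cells (Homo sapiens) for inhibition, read by MTT assay, with a stated time of 72 h (a lower number here means a stronger inhibitor, a higher number a weaker inhibitor), compound 1 (`COc1cc(O)c(CC=C(C)C)c(O)c1C(=O)/C=C/c1ccc(Cl)cc1`) gives 16500 nM. Compound 2 (`COc1cc(O)cc(O)c1C(=O)/C=C/c1ccc(C)cc1`) is reported only as > 50000 nM in this assay, and this is a limit of the assay, not a number.

The next entry, compound 3 (`COc1cc(O)cc(O)c1C(=O)/C=C/c1ccc(Cl)cc1`), comes from compound 2 by one change, chloro in place of methyl on an aromatic carbon, the 4-methylphenyl becoming 4-chlorophenyl. Within the data shown here, no measured step shows this change on its own. Compound 1 also holds the 4-chlorophenyl group and reads 16500 nM, which leaves a readable number possible. In this assay the expected at least 1.1-fold lower number from compound 2 to compound 3 (0.04 log units; that floor lies within the scatter) is small, towards lower numbers if it shows at all, and may not clear the scatter. For compound 3 the estimated value is 45000 nM, with an expected range of 20000 nM to 100000 nM.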

Compound 3, half-maximal inhibitory concentration: 17000 nM
The estimate for compound 3 lay 2.6-fold (0.42 log units) above the measured number; measured number below the stated range.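

In this assay, 4-chlorophenyl in place of 4-methylphenyl on the shared core gives the first readable gain at this position (an at least 2.9-fold lower number from compound 2 to compound 3 (0.46 log units; beyond the scatter)). That step is a floor and not a full size because compound 2 carries a limit and not a number: the limit of > 50000 nM in this assay, at which 1 of the 3 values shown sits. Hydrogen in place of 3-methylbut-2-en-1-yl, with 4-chlorophenyl kept, stays within the scatter (a 1.0-fold higher number from compound 1 to compound 3 (0.01 log units; within the scatter)), so in this pair the chain contributes no readable difference.

On these data alone, the true size of the chloro step remains open, as does whether it is specific to chlorine or would also appear with fluoro, bromo or a nitrile at the same place. Also open, as far as these compounds go, is whether 3-methylbut-2-en-1-yl would stay as silent on the 4-methylphenyl compounds, or whether a shorter chain such as ethyl would read differently.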